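The source may hold more compounds than are shown below. What is called first, only, known or untested is meant among the compounds shown, and "the series" means these compounds.

Compound 1 `CN1CCN(CCNCc2cn(-c3ccc(F)cc3F)nc2-c2ccc(Cl)cc2)CC1` and compound 2 `CN1CCN(CCNCc2cn(-c3ccc(F)cc3F)nc2-c2cccc(N(C)C)c2)CC1` share one core and differ only in the group carried on one aromatic carbon of that core. In an ADME assay on Huh-7 cells (Homo sapiens) for cytotoxicity (a lower number here means that less compound is tolerated, a higher number that more compound is tolerated), compound 1 gives 19000 nM. For compound 2 the result in this assay is > 20000 nM, and this is a limit of the assay rather than a number. Compound 2 therefore sits at the limit of > 20000 nM in this assay, at which 1 of the 2 values shown sits, so where it truly stands is known only as a range. The step of an at least 1.0-fold higher number from compound 1 to compound 2 (0.02 log units; that floor lies within the scatter) lies within the scatter of repeated measurements.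

Compound 3 `CN1CCN(CCNCc2cn(-c3ccc(F)cc3F)nc2C(C)(C)C)CC1` is not yet measured. It differs from compound 2 in one place: tert-butyl in place of 3-(dimethylamino)phenyl on an aromatic carbon. Among the measured compounds shown here, the only measured step, that from compound 1 to compound 2, gave no change beyond the scatter, so the groups on this position have so far left the read-out unmoved. On that basis no step beyond the scatter is expected in this assay from compound 2 to compound 3, that is a number no higher from compound 2 to compound 3 (the limit leaves the size open). Compound 3 is estimated at 20000 nM, with a range from 10000 nM to 40000 nM.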

Compound 3, half-maximal cytotoxic concentration: > 20000 nM
Compound 3 gave a limit, no number (the forecaster's own chance of this, stated with the estimate: 55%); the middle value lies on the limit itself.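

Compound 3 carries tert-butyl, a group with no ring, where compound 1 and compound 2 carry a substituted phenyl ring, and in this assay compound 3 gives > 20000 nM, which is a limit of the assay and not a number. Set against the chlorine-bearing ring, this change gives an at least 1.0-fold higher number from compound 1 to compound 3 (0.02 log units; that floor lies within the scatter), so a group without a ring on this aromatic carbon shows no tolerated concentration lower than that of compound 1, although the true size of the step stays unknown. The step between the two compounds that carry tert-butyl and 3-(dimethylamino)phenyl cannot be read, because both sit at the same limit: the limit of > 20000 nM in this assay, at which 2 of the 3 values shown sit.

On these data alone, how far the true values of compound 2 and compound 3 lie past that limit remains open, so any real difference between these two groups stays hidden. Also open, as far as these compounds go, is whether a group of another kind on this aromatic carbon, such as a carboxylic acid or a primary amine, would bring the read-out down to a measurable number.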